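Sec-butyl for cyclobutylmethyl: half-life notes

A few compounds are considered here, and "the series" means these few. Any claim that something is new, unique, unknown or untested is made for them only; others in the source may bear on it.

Values from an in vitro ADME assay on microsomes from liver (Homo sapiens) for metabolic stability, tested at 5 uM (a higher number here means that the compound lasts longer, a lower number that the compound disappears faster), follow
compound 1 `CC(C)CCn1nc(-c2cccs2)c(O)c(C2=NS(=O)(=O)c3cc(N(C)S(C)(=O)=O)ccc3N2)c1=O` gives 0.467 h
compound 2 `CC(C)CCn1nc(C2CCC2)c(O)c(C2=NS(=O)(=O)c3cc(NS(C)(=O)=O)ccc3N2)c1=O` gives 0.317 h
compound 3 `CS(=O)(=O)Nc1ccc2c(c1)S(=O)(=O)N=C(c1c(O)c(-c3cccs3)nn(CC3CCC3)c1=O)N2` gives > 1 h as a limit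

For compound 3 only a limit is reported (the limit of > 1 h in this assay, at which 1 of the 3 values shown sits) and no number is known. Compound 4 `CCC(C)n1nc(-c2cccs2)c(O)c(C2=NS(=O)(=O)c3cc(NS(C)(=O)=O)ccc3N2)c1=O` awaits measurement. The change from compound 3 to compound 4 is sec-butyl in place of cyclobutylmethyl on an aromatic nitrogen and the rest of the structure stays the same.

Among the measured compounds shown here, no two measured compounds differ in one place only, so no measured step bears directly on this change. The nearest guide is weak. Compound 1 (0.467 h) and compound 2 (0.317 h) carry no ring on that nitrogen, as compound 4 will, but both also differ from compound 3 elsewhere. A shortening of modest size is therefore expected in this assay, estimated as an at least 1.2-fold lower number from compound 3 to compound 4 (0.09 log units; that floor lies within the scatter) and possibly no larger than the usual scatter. For compound 4 the estimate is 0.8 h with an expected range from 0.4 h to 1.5 h and an outcome that is only a limit remains possible.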

Compound 4, half-life: > 1 h
Compound 4: a limit, no number (the forecaster's own chance of this, stated with the estimate: 35%); middle value at least 1.2-fold (0.09 log units) from the limit.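

In this assay compound 4 gives > 1 h, a limit, and compound 3 is also reported only as a limit, so no step between compound 3 and compound 4 can be read: the limit of > 1 h in this assay, at which 2 of the 4 values shown sit.

The compounds shown leave open whether sec-butyl in place of cyclobutylmethyl on an aromatic nitrogen changes the half-life at all, and in which direction.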